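Working notes: methoxy to hydroxy from compound 1

The compounds below may be only part of what the source reports. "The series", "measured", "known", "first", "only" and "open" are said of these compounds alone.

Measured so far in a functional assay on MCF7 cells (Homo sapiens) for inhibition, with a stated time of 72 h (on this read-out lower numbers stand for stronger inhibition of growth and higher numbers for weaker inhibition of growth), for this series:
- compound 1 `CCN(CC)S(=O)(=O)c1ccc(OC)c(NC(=O)c2[nH]c(C)c3c2CCCCC3=O)c1` gives 6840 nM
- compound 2 `COc1ccc(S(=O)(=O)N2CC3(COC3)C2)cc1NC(=O)c1[nH]c(C)c2c1CCCCC2=O` gives 5760 nM
- compound 3 `CCc1c(C(=O)Nc2cc(S(=O)(=O)N(CC)CC)ccc2O)[nH]c(C)c1C(C)=O` gives "not determined" (no result reported)

Only compound 1 and compound 2 carry numbers, and these lie within the scatter of each other, so compound 1 holds no separate place in the series. Compound 3 adds no number to compare.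

The next compound is compound 4 `CCN(CC)S(=O)(=O)c1ccc(O)c(NC(=O)c2[nH]c(C)c3c2CCCCC3=O)c1` and its change from compound 1 is hydrogen in place of methyl on an oxygen on an aromatic ring in the form of hydrogen in place of methyl on an oxygen on an aromatic ring, methoxy to hydroxy.

Among the measured compounds shown here, the one measured step is a 1.2-fold lower number from compound 1 to compound 2 (0.07 log units; within the scatter) and it sits on a sulfonyl sulfur, not at this oxygen. It therefore bears only indirectly: it shows a change elsewhere in the molecule that left this assay within the scatter, and it says nothing about the direction of a change at the oxygen. For the measured compounds named here, no measured pair covers methoxy to hydroxy, so the range has to stay wide.

On these data alone, no shift beyond the scatter is expected, and the direction remains open. The expected step is a 1.2-fold lower number from compound 1 to compound 4 (0.09 log units; within the scatter) and it should be read as no real change. For compound 4 the estimated value is 5500 nM with an expected range from 1800 nM to 16000 nM in this read-out.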

Compound 4, concentration for 50% growth inhibition: > 40000 nM
Compound 4: only a limit was reported (the forecaster's own chance of this, stated with the estimate: 10%); middle value at least 7.2-fold (0.86 log units) from the limit.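

In this assay, among the compounds shown here, hydrogen in place of methyl on an oxygen on an aromatic ring gives an at least 5.8-fold higher number from compound 1 to compound 4 (0.76 log units; beyond the scatter), so methoxy to hydroxy weakens inhibition of growth, the first change to do so beyond the scatter. The result for compound 4 is a limit and not a number, so the step has a lower bound but no measured size: the limit of > 40000 nM in this assay, at which 1 of the 4 values shown sits. For the compounds shown here, the only earlier step, at a different place, is a 1.2-fold lower number from compound 1 to compound 2 (0.07 log units; within the scatter), so this oxygen on the aromatic ring is the first place where a change moves the read-out.

Only methoxy and hydroxy are compared at this oxygen, so the compounds shown do not tell whether the methyl itself matters or whether an ethoxy group or a longer chain on the oxygen would serve equally well. They also leave open whether a group such as an amine or fluorine in place of the hydroxy would differ from compound 4, and compound 3, which also carries a hydroxy, supplies no number to help.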